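A few compounds are considered here, and "the series" means these few. Any claim that something is new, unique, unknown or untested is made for them only; others in the source may bear on it.

Of the compounds shown here, three built on one shared core have been measured in a physicochemical assay for lipophilicity; a lower number here means a more polar compound, a higher number a more lipophilic compound. Compound 1 `COCCOCn1cc[n+](C)c1/C=N/O` gives -2.81, compound 2 `C[n+]1ccn(COCC[Si](C)(C)C)c1/C=N/O` gives -0.34, and compound 3 `C[n+]1ccn(COCCCCCl)c1/C=N/O` gives -1.47. Compound 3 therefore stands second highest of the three: its nearest neighbour is compound 2, separated by the step of a number 1.13 log units lower from compound 2 to compound 3 (beyond the scatter), and its furthest is compound 1, separated by the step of a number 1.34 log units higher from compound 1 to compound 3 (beyond the scatter), both beyond the scatter.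

Compound 4 `C[n+]1ccn(COCC(C)(C)CBr)c1/C=N/O` differs from compound 3 in a single place: a group of 5 heavy atoms (4 carbon, 1 bromine; no ring) in place of a group of 4 heavy atoms (3 carbon, 1 chlorine; no ring), on a saturated chain carbon bound to an oxygen on a saturated carbon. The earlier steps shown here that bear on this change are those altering the same side chain, namely a number 1.34 log units higher from compound 1 to compound 3 (beyond the scatter) and a number 2.47 log units higher from compound 1 to compound 2 (beyond the scatter), and both were large, with the bulkier, heavier chain always giving the higher reading in this assay. The change to compound 4 is more modest than either of those, so a clear but smaller rise is expected; the expected step is a number 0.77 log units higher from compound 3 to compound 4 (beyond the scatter). Compound 4 is accordingly expected to give -0.7, within a range from -1.2 to -0.2.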

Compound 4, distribution coefficient: -0.81
Estimate against measurement, compound 4: 0.11 log units above; the measured number falls inside the stated range.
By their numbers in this assay, from the lowest: compound 1; then compound 3; then compound 4; then compound 2.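

In this assay, the change on a saturated chain carbon bound to an oxygen on a saturated carbon gives a number 0.66 log units higher from compound 3 to compound 4 (beyond the scatter) and so replaces 3-chloropropyl with a bromine-bearing group of 5 heavy atoms at a modest gain. The silicon-bearing chain of compound 2 still gives the highest number, with a number 0.47 log units lower from compound 2 to compound 4 (beyond the scatter) showing that two groups of 5 heavy atoms can read differently when one carries silicon and the other bromine. The widest new gap is a number 2.00 log units higher from compound 1 to compound 4 (beyond the scatter) and all four compounds now stand apart beyond the scatter.

Nothing here gives a measured reason for these steps. Open too, on these data alone, is how a 3-bromopropyl chain, which would separate the bromine from the added carbons, or an amine at the chain end would read in this assay on the shared core.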